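Exchanging a pyridinyl amine for a dichlorophenyl amine

The source may hold more compounds than are shown below. What is called first, only, known or untested is meant among the compounds shown, and "the series" means these compounds.

Compound 1 `CN1C(=O)C(CCO[Si](c2ccccc2)(c2ccccc2)C(C)(C)C)COC12C=CC(=O)C=C2` gives 679 nM in an assay on isolated protein for inhibition of N-lysine methyltransferase SMYD2 (Homo sapiens), read by filter binding, with a stated time of 1 h; on this read-out lower numbers stand for stronger inhibition and higher numbers for weaker inhibition.
Compound 2 `CN1C(=O)C(CCO)COC12C=CC(=O)C=C2` gives > 30000 nM, a limit of the assay rather than a number.
Compound 3 `CN1C(=O)C(CCNc2cccnc2)COC12C=CC(=O)C=C2` gives > 20000 nM, also a limit rather than a number.

Going by the values given here, compound 3 therefore stands at the limit of > 20000 nM in this assay, at which 1 of the 3 values shown sits, and the only measured step that reaches it, a step that the two limits leave unreadable from compound 2 to compound 3, cannot be sized, because compound 2 sits at the limit of > 30000 nM in this assay, at which 1 of the 3 values shown sits. Among the compounds with values here, compound 1 is the only one of the three with a true number, and no single-place step joins it to compound 3.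

Compound 4 `CN1C(=O)C(CCNc2ccc(Cl)c(Cl)c2)COC12C=CC(=O)C=C2` differs from compound 3 in one place: 3,4-dichlorophenyl in place of pyridin-3-yl on an amine nitrogen. Within the data shown here, no measured step bears on this exchange, so there is nothing to set a size or a direction for it; the one step that touches compound 3 is unreadable.

The estimate for compound 4 is 15000 nM, within 3000 nM to 40000 nM. The step of an at least 1.3-fold lower number from compound 3 to compound 4 (0.12 log units; that floor lies within the scatter) is expected to stay hard to read, since compound 3 is known only as a limit.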

Compound 4, half-maximal inhibitory concentration: 3820 nM
Compound 4: middle estimate off by 3.9-fold (0.59 log units), on the high side; low and high end bracket the measured number.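

The exchange of pyridin-3-yl for 3,4-dichlorophenyl on the amine nitrogen brings an at least 5.2-fold lower number from compound 3 to compound 4 (0.71 log units; beyond the scatter) in this assay. Going by these compounds alone, this is the first readable step at this position, and it shows that the ring carried on this nitrogen can change the read-out, which the earlier compounds could not show. Only a floor for the size of the step is known, because compound 3 is a limit: the limit of > 20000 nM in this assay, at which 1 of the 4 values shown sits.

The compounds shown do not separate the loss of the ring nitrogen from the arrival of the two chlorines, and a plain phenyl or a phenyl with a single chlorine on this amine would pull the two apart. On these data alone, how a longer chain between the core and the amine nitrogen would move the number also remains open.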